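Dropping the Aromatic Hydroxy: From Compound 3 to Compound 4

A few compounds are considered here, and "the series" means these few. Any claim that something is new, unique, unknown or untested is made for them only; others in the source may bear on it.

Compound 1, `Cc1ccc([C@]2(CO)NC[C@@H](O)[C@@H]2O)cc1`: 1.6%
Compound 2, `OC[C@@]1(c2cccc(F)c2)NC[C@@H](O)[C@@H]1O`: 0%
Compound 3, `OC[C@@]1(c2ccc(O)cc2)NC[C@@H](O)[C@@H]1O`: 1.2%

Three compounds sharing one core and differing only in the group carried on the aromatic ring have been tested in an assay on isolated protein for inhibition of alpha-galactosidase (Coffea arabica), tested at 1000 uM; on this read-out lower numbers stand for less inhibition and higher numbers for more inhibition at the one concentration tested (going by the name of the read-out). Compound 3 gives 1.2%, the second highest of the three numbers; compound 1 gives 1.6% and compound 2 gives 0%. All three lie within the scatter of one another, so none of the three numbers can be called higher or lower than the others; all of them sit near zero.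

Compound 4, `OC[C@@]1(c2ccccc2)NC[C@@H](O)[C@@H]1O`, differs from compound 3 in one place: hydrogen in place of hydroxy on an aromatic carbon. Among the compounds with values here, the only measured step on an aromatic carbon of this ring, a number 0.4 percentage points lower from compound 1 to compound 3 (within the scatter), stayed within the scatter. Within the data shown here, no measured pair shows a hydrogen entering in place of hydroxy, but because every group tried so far leaves 1.2% and its neighbours near zero, the step of a number 0.3 percentage points higher from compound 3 to compound 4 (within the scatter) is expected to be none beyond the scatter. Compound 4 is therefore expected to give 1.5%, within a range from 0% to 8%.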

Compound 4, a percentage reported as inhibition, at one concentration (the size of the read-out at that concentration, not a potency): 9.9%
Compound 4: middle estimate off by 8.4 percentage points, on the low side; the whole stated range lies below it.
By their numbers in this assay, from the lowest: compounds 2, 3, 1 and 4 (each within the scatter of the next).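

In this assay the plain ring of compound 4, with hydrogen in place of hydroxy (a number 8.7 percentage points higher from compound 3 to compound 4 (within the scatter)), fluoro (a number 9.9 percentage points higher from compound 2 to compound 4 (within the scatter)) or methyl (a number 8.3 percentage points higher from compound 1 to compound 4 (within the scatter)), lies within the scatter of all three substituted compounds. So the group can be removed from the aromatic ring altogether, and none of the groups shown can be told apart from plain hydrogen on this read-out. Nothing available accounts for these numbers. The compounds shown leave open whether an amine, a carboxylic acid or a longer chain on this aromatic ring would give a number beyond the scatter of compound 4. They also leave open how these compounds would compare if tested at more than one concentration.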